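The compounds below may be only part of what the source reports. "The series", "measured", "known", "first", "only" and "open" are said of these compounds alone.

Measured so far:
- compound 1 `CN1CCc2nc(C#Cc3ccccc3)sc2C1`; in an assay on HEK293 cells for negative allosteric modulation of metabotropic glutamate receptor 5 (Homo sapiens), read by FLIPR, with a stated time of 1 h (on this read-out higher numbers stand for weaker inhibition and lower numbers for stronger inhibition), compound 1 gives > 10000 nM, which is a limit of the assay and not a number.
- compound 2 `CC(C)CN1CCc2nc(C#Cc3ccccc3)sc2C1`; in this assay compound 2 gives 650 nM.
- compound 3 `O=C(C1CC(F)C1)N1CCc2nc(C#Cc3ccccc3)sc2C1`; in this assay compound 3 gives > 10000 nM, again a limit of the assay.

Compound 3 thus stands at the limit (the limit of > 10000 nM in this assay, at which 2 of the 3 values shown sit), with no number known for it. Of the two steps that arrive at compound 3, the step that the two limits leave unreadable from compound 1 to compound 3 cannot be read, whereas an at least 15-fold higher number from compound 2 to compound 3 (1.18 log units; beyond the scatter) is readable and large.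

Compound 4 `O=C(C1CCCCC1)N1CCc2nc(C#Cc3ccccc3)sc2C1` keeps the amide on the ring nitrogen and differs from compound 3 only by cyclohexyl in place of 3-fluorocyclobutyl on a carbonyl carbon. For the measured compounds named here, none of the measured steps changes the group on the carbonyl carbon; both steps that reach compound 3 exchange the whole substituent on the ring nitrogen, so they give no size for this change. Going by the values given here, only the weak position of compound 3 is known, and the measured steps suggest that an acyl group on the ring nitrogen is unfavourable in this assay, with no compound going against it among those measured.

Compound 4 is therefore expected to stay at the limit, so that a step that the limit leaves unreadable from compound 3 to compound 4 is expected to show no change beyond the scatter. For compound 4 the estimate in this assay is 12000 nM, with a range from 3000 nM to 40000 nM, and most likely only a limit will again be reported.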

Compound 4, half-maximal inhibitory concentration: > 10000 nM
Compound 4: a limit, no number; the forecaster's own chance of this, stated with the estimate: 75%; the middle value lies beyond the limit too.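

In this assay compound 4 gives > 10000 nM, which is a limit of the assay and not a number. Cyclohexylcarbonyl on the ring nitrogen thus joins (3-fluorocyclobutyl)carbonyl as a second acyl group without a readable value, and set against the isobutyl group the change gives an at least 15-fold higher number from compound 2 to compound 4 (1.18 log units; beyond the scatter). The steps from compound 3 to compound 4 and from compound 1 to compound 4 cannot be read, so the exchange on the carbonyl carbon has no size, and the limit is not confined to the amides, since compound 1 with its methyl group shares it: the limit of > 10000 nM in this assay, at which 3 of the 4 values shown sit.

Still open, from the compounds shown here alone, is whether any acyl group on the ring nitrogen gives a number in this assay, for instance a carbamate, a urea or an acyl group carrying an amine. Also open, going by these compounds, is how much the ring nitrogen's substituent must resemble isobutyl, which a cyclohexylmethyl group, a benzyl group or a longer chain there would help to settle, with cyclohexylmethyl differing from compound 4 only at the carbonyl.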